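The compounds below may be only part of what the source reports. "The series", "measured", "known", "first", "only" and "open" are said of these compounds alone.

In a functional assay on SMMC-7721 cells (Homo sapiens) for cytotoxicity, read by MTT assay, with a stated time of 24 h (a higher number here means a weaker inhibitor, a lower number a stronger inhibitor), compound 2 (`O=C1/C(=C/c2cccc([N+](=O)[O-])c2)CN(S(=O)(=O)c2ccc(F)cc2)C/C1=C\c1ccccc1F`) gives 7820 nM. Compound 3 (`COc1cc(/C=C2\CN(S(=O)(=O)c3ccc(F)cc3)C/C(=C\c3ccccc3F)C2=O)cc(OC)c1`) gives 6890 nM, within the scatter of compound 2, while compound 1 (`COc1cc(/C=C2\CN(S(=O)(=O)c3ccc(F)cc3)C/C(=C\c3cc(OC)c(OC)c(OC)c3)C2=O)cc(OC)c1OC`) gives 3840 nM, a lower number than compound 2 shows, beyond the scatter. Compound 4 (`COc1cc(/C=C2\CN(S(=O)(=O)c3ccc(F)cc3)C/C(=C\c3cccc([N+](=O)[O-])c3)C2=O)cc(OC)c1OC`) departs from compound 2 by 3,4,5-trimethoxyphenyl in place of 2-fluorophenyl on a double-bonded chain carbon bound to a double-bonded ring carbon. Among the measured compounds shown here, no measured step makes this exchange directly. For the measured compounds named here, the one measured step, a 1.1-fold lower number from compound 2 to compound 3 (0.05 log units; within the scatter), concerns the 3-nitrophenyl group instead, and it is small. Compound 1 does carry 3,4,5-trimethoxyphenyl, and it gives 3840 nM. A small move towards a lower number, not clearly beyond the scatter, is therefore expected. The expected step is a 1.5-fold lower number from compound 2 to compound 4 (0.17 log units; within the scatter). For compound 4 the estimated value is 5300 nM, with an expected range of 2500 nM to 11000 nM.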

Compound 4, half-maximal inhibitory concentration: 4900 nM
Compound 4: middle estimate off by 1.1-fold (0.03 log units), on the high side; the measured number falls inside the stated range.
By their numbers in this assay, from the lowest: compounds 1, 4, 3 and 2 (each within the scatter of the next, the first and the last beyond it).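

In this assay the exchange of 2-fluorophenyl for 3,4,5-trimethoxyphenyl on a double-bonded chain carbon bound to a double-bonded ring carbon can now be read directly, and it stays within the scatter (a 1.6-fold lower number from compound 2 to compound 4 (0.20 log units; within the scatter)). Putting 3-nitrophenyl in place of 3,4,5-trimethoxyphenyl at this place also stays within the scatter (a 1.3-fold higher number from compound 1 to compound 4 (0.11 log units; within the scatter)). No measurement at hand bears on why these steps are small. The compounds shown leave open whether an aryl ring carrying an amine or a carboxylic acid at this place would move the number beyond the scatter.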